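From Isopropylamino to 4-Methylpiperazin-1-yl on a Carbonyl Carbon

A few compounds are considered here, and "the series" means these few. Any claim that something is new, unique, unknown or untested is made for them only; others in the source may bear on it.

Of the compounds shown here, three have been tested so far in a functional assay on the whole organism with Mus musculus as the target; a lower number here means that less compound is needed, a higher number that more compound is needed for the effect. Within the data shown here, compound 1 `CCC(O)CNC(=O)/C=C/c1cccc(C(F)(F)F)c1` gives 64.4 mg/kg, the only actual number among the three. Compound 2 `CCN1C(=O)CCC1(O)c1cccc(C(F)(F)F)c1` reads > 75 mg/kg, which is a limit of the assay and not a number. Compound 3 `CC(C)NC(=O)CCC(=O)c1cccc(C(F)(F)F)c1` reads > 150 mg/kg, which is also a limit and not a number, so its standing is known only as a limit.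

Compound 4 `CN1CCN(C(=O)CCC(=O)c2cccc(C(F)(F)F)c2)CC1` keeps the core of compound 3 and changes one group, with 4-methylpiperazin-1-yl in place of isopropylamino on a carbonyl carbon. The new group brings a six-membered non-aromatic ring with 2 hetero atoms.

Among the measured compounds shown here, no two measured compounds differ in just one place, so the data do not show how large a single change tends to be in this assay. The expected step, an at least 1.2-fold lower number from compound 3 to compound 4 (0.09 log units; that floor lies within the scatter), is estimated to stay within the usual scatter, in neither direction. Compound 4 is estimated at 120 mg/kg, with an expected range from 50 mg/kg to 300 mg/kg.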

Compound 4, dose for half-maximal effect: > 37.5 mg/kg
Compound 4 ended at the assay's limit; the forecaster's own chance of this, stated with the estimate: 50%; the middle value is on the limit's open side.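

Among these compounds, compound 3 and compound 4 each ended at a limit of the assay and not at a number, so no step between them can be read. The compounds shown leave open whether 4-methylpiperazin-1-yl in place of isopropylamino on a carbonyl carbon changes the dose needed in this assay.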